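A Thiazole in Place of a Pyridine

This account rests on a few compounds, and the source may have more. Where it says the series, first, only, none or still open, it means among the compounds named here.

Among the compounds with values here, compound 1 `Cc1ccc(N/C(S)=N/[C@H](C)c2cccc3ccccc23)nc1` gives 5 nM in a functional assay on RBL-2H3 cells (Rattus norvegicus) for inhibition (on this read-out higher numbers stand for weaker inhibition and lower numbers for stronger inhibition), and holds the only number among the two values shown. Compound 2 `Cc1ccc(N/C(S)=N/[C@@H](C)c2cccc3ccccc23)nc1` reaches only a limit of the assay, > 100000 nM. The step of an at least 20000-fold higher number from compound 1 to compound 2 (4.30 log units; beyond the scatter) rests on (the fact that compounds 1 and 2 differ only in the configuration as drawn), a change of a wholly different kind from the one considered here. Compound 3 `Cc1csc(N/C(S)=N/[C@H](C)c2cccc3ccccc23)n1` is yet to be measured. It differs from compound 1 by 4-methyl-1,3-thiazol-2-yl in place of 5-methylpyridin-2-yl on an amine nitrogen. Within the data shown here, no measured step bears on this exchange, so the expected step of a 3.0-fold higher number from compound 1 to compound 3 (0.48 log units; beyond the scatter) is estimated as one within the scatter, though with a wide range. Compound 3 is expected at 15 nM, between 2 nM and 150 nM.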

Compound 3, half-maximal inhibitory concentration: 25900 nM
Estimate against measurement, compound 3: 1700-fold (3.24 log units) below; the whole stated range lies below it.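

In this assay, 4-methyl-1,3-thiazol-2-yl in place of 5-methylpyridin-2-yl on the amine nitrogen gives a 5200-fold higher number from compound 1 to compound 3 (3.71 log units; beyond the scatter). The earlier compounds shown here showed a large step only for a change of configuration, whereas this one shows that the aromatic group on this nitrogen can also carry a large step with the configuration unchanged. Nothing shown here explains the size of this step.

From the compounds shown here alone, whether the ring size, the sulfur or the methyl placement matters most stays open. So does what a plain phenyl or an unsubstituted pyridin-2-yl would give on the same nitrogen.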